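The source may hold more compounds than are shown below. What is called first, only, known or untested is meant among the compounds shown, and "the series" means these compounds.

Compound 3, `Cc1nc(C)c(CSc2nnnn2C)nc1C`, was tested in a functional assay on a cell-free system (Platelet, plasma, Oryctolagus cuniculus) for inhibition, with a stated time of 5 min; on this read-out higher numbers stand for weaker inhibition and lower numbers for stronger inhibition. In this assay compound 3 gives only a limit of the assay, > 2000000 nM, and not a number. The same holds for compound 1, `Cc1nc(C)c(COC(=O)CCCC[C@@H]2CCSS2)nc1C`, which in this assay also gives only a limit, > 2000000 nM. For the measured compounds named here, compound 2, `Cc1nc(C)c(CSc2nnc(-c3cccs3)n2N)nc1C`, is the one compound that gives a number, 810000 nM. The value of compound 3 is the limit of > 2000000 nM in this assay, at which 2 of the 3 values shown sit, so compound 3 stands at the weak end of what this assay can show. The next compound, compound 4, `Cc1nc(C)c(CSc2nnnn2-c2ccccc2)nc1C`, differs from compound 3 in one place: phenyl in place of methyl on an aromatic nitrogen. Going by the values given here, no measured pair shows a change of this kind, so there is no measured step to lean on. Since compound 3 sits at the limit, only a move towards stronger inhibition could appear as a number; the expectation is a small gain at most, close to the scatter, with the estimated step being an at least 1.3-fold lower number from compound 3 to compound 4 (0.12 log units; that floor lies within the scatter). For compound 4 the expected value in this assay is 1500000 nM, with a range from 300000 nM to 5000000 nM.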

Compound 4, half-maximal inhibitory concentration: > 2000000 nM
Compound 4: only a limit was reported (the forecaster's own chance of this, stated with the estimate: 60%); middle value at least 1.3-fold (0.12 log units) from the limit.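

For the compounds shown here, compound 3 and compound 4 both give only a limit in this assay, so no step between them can be read: the limit of > 2000000 nM in this assay, at which 3 of the 4 values shown sit. From the compounds shown here alone, whether phenyl in place of methyl on the aromatic nitrogen changes inhibition at all stays open.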